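The source may hold more compounds than are shown below. What is called first, only, known or untested is meant among the compounds shown, and "the series" means these compounds.

Measured in an ADME assay on HepG2 cells (Homo sapiens) for cytotoxicity, read by MTT assay, with a stated time of 72 h; a higher number here means that more compound is tolerated, a lower number that less compound is tolerated:
compound 1, `N#Cc1ccc(-c2cc(Cl)cn3c([N+](=O)[O-])c(CS(=O)(=O)c4ccccc4)nc23)cc1`: > 3900 nM
compound 2, `O=[N+]([O-])c1c(CS(=O)(=O)c2ccccc2)nc2c(-c3ccc(O)cc3)cc(Cl)cn12`: > 12500 nM
compound 3, `O=[N+]([O-])c1c(CS(=O)(=O)c2ccccc2)nc2c(-c3cccc(CO)c3)cc(Cl)cn12`: > 25000 nM

Each of these three values is a limit of the assay and not a number. Compound 3 sits at the limit of > 25000 nM in this assay, at which 1 of the 3 values shown sits. Compound 2 sits at the limit of > 12500 nM in this assay, at which 1 of the 3 values shown sits. Compound 1 sits at the limit of > 3900 nM in this assay, at which 1 of the 3 values shown sits. Since all three are limits, none of the pairwise comparisons can be read: a step that the two limits leave unreadable from compound 1 to compound 3 and a step that the two limits leave unreadable from compound 2 to compound 3 and a step that the two limits leave unreadable from compound 1 to compound 2 are all of unreadable size, and no order among the three compounds can be stated. Compound 3 stands at a limit, with nothing placing it above or below the other two.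

Compound 4, `O=[N+]([O-])c1c(CS(=O)(=O)c2ccccc2)nc2c(-c3cccnc3)cc(Cl)cn12`, has not yet been measured in this assay. It differs from compound 3 in one place: pyridin-3-yl in place of 3-(hydroxymethyl)phenyl on an aromatic carbon

Among the compounds with values here, the steps that bear on this change are those that also exchange the aryl group on the shared core, a step that the two limits leave unreadable from compound 1 to compound 3 and a step that the two limits leave unreadable from compound 2 to compound 3; both are unreadable, so they give no direction and no size. Compound 4 is therefore expected to be tolerated to a similar extent as compound 3, most likely again as a limit, with an expected step of an at least 1.2-fold lower number from compound 3 to compound 4 (0.09 log units; that floor lies within the scatter). The estimate for compound 4 is 20000 nM, expected to lie between 7000 nM and 50000 nM.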

Compound 4, half-maximal cytotoxic concentration: > 31300 nM
Compound 4 ended at the assay's limit; the forecaster's own chance of this, stated with the estimate: 70%; middle value at least 1.5-fold (0.19 log units) from the limit.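

In this assay compound 4 gives > 31300 nM, again a limit of the assay, so its steps from compound 1, compound 2 and compound 3 cannot be read. The compounds shown leave open whether exchanging the aryl group on the shared core changes the tolerated concentration at all.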